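A Chloro for Fluoro Exchange on Compound 2

The source may report more compounds than this note shows. Statements on the series, on what has been measured and on what is new or still open speak of the compounds shown alone.

Values so far in a functional assay on Jurkat cells (Homo sapiens) for cytotoxicity, read by luminescence and CellTiter-Glo, with a stated time of 3 days; a higher number here means a weaker inhibitor, a lower number a stronger inhibitor:
Compound 1 `O=C(Nc1ccc(OC(F)(F)F)cc1)c1cc(F)ccc1O`: 810 nM
Compound 2 `O=C(Nc1ccc(OC(F)(F)F)c(Cl)c1)c1cc(F)ccc1O`: 700 nM

Compound 2 gives 700 nM in this assay and cannot be separated from compound 1 on these numbers, since the two lie within the scatter of each other. Compound 3 `O=C(Nc1ccc(OC(F)(F)F)c(Cl)c1)c1cc(Cl)ccc1O` has not yet been measured. It differs from compound 2 in one place: chloro in place of fluoro on an aromatic carbon that is, chloro in place of fluoro on an aromatic carbon, para to a hydroxy group.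

Among the measured compounds shown here, only one measured step bears on this, and it is an indirect guide. That step is a 1.2-fold lower number from compound 1 to compound 2 (0.06 log units; within the scatter) and it involved chloro in place of hydrogen on an aromatic carbon, at another place in the structure. For the measured compounds named here, no measured pair shows an exchange of fluoro for chloro, so the expectation rests on this single small step. No change beyond the scatter is therefore expected, and the estimate is a 1.3-fold lower number from compound 2 to compound 3 (0.10 log units; within the scatter) in this assay as the expected step. For compound 3 the estimated value is 550 nM with an expected range from 250 nM to 1200 nM in this assay as measured.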

Compound 3, half-maximal inhibitory concentration: 840 nM
For compound 3 the middle estimate is 1.5-fold (0.18 log units) below the measured one; the range from low to high includes it.
By their numbers in this assay, from the lowest: compounds 2, 1 and 3 (each within the scatter of the next).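

Among the compounds shown here, the exchange of fluoro for chloro on the aromatic carbon para to a hydroxy group gives, in this assay, a 1.2-fold higher number from compound 2 to compound 3 (0.08 log units; within the scatter), and this is the first direct reading at this position, since the earlier step concerned another place in the structure. Within the compounds shown, then, this position holds either fluoro or chloro with no change that this assay can separate from the scatter, although this rests on a single pair and says nothing about other replacements at this carbon. No measurement is available that would help interpret this result beyond the cytotoxicity numbers themselves.

What the compounds shown leave open is whether a group of a different kind at this position, such as an amine, a methoxy group or a nitrile, would leave the number just as undisturbed or would move it well beyond the scatter. On these data alone, it is also open whether the same exchange of fluoro for chloro would read the same way on the core of compound 1, which lacks the added chloro of compound 2.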